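Swapping the aryl group on the saturated ring carbon

A few compounds are considered here, and "the series" means these few. Any claim that something is new, unique, unknown or untested is made for them only; others in the source may bear on it.

Of the compounds shown here, three that share one core have been measured. Compound 1, `COc1cc(N2C(N)=C(C#N)C(c3c(O)ccc4ccccc34)C3=C2CC(C)(C)CC3=O)cc(OC)c1OC`, gives 90% in a functional assay on Ehrlich cells (Mus musculus) for cytotoxicity, tested at 100 ug/mL; on this read-out lower numbers stand for a weaker effect and higher numbers for a stronger effect at the one concentration tested. Compound 2, `COc1cc(N2C(N)=C(C#N)C(c3cccc([N+](=O)[O-])c3)C3=C2CC(C)(C)CC3=O)cc(OC)c1OC`, gives 30% in this assay. Compound 3, `COc1cc(N2C(N)=C(C#N)C(c3ccccc3Cl)C3=C2CC(C)(C)CC3=O)cc(OC)c1OC`, gives 20% in this assay, the lowest of the three numbers; compound 2 is nearest to it, within the scatter, while compound 1 stands furthest away, beyond the scatter.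

Compound 4, `COc1cc(N2C(N)=C(C#N)C(c3ccc(C)cc3)C3=C2CC(C)(C)CC3=O)cc(OC)c1OC`, is the next one to be tested. It differs from compound 3 only in one place: 4-methylphenyl in place of 2-chlorophenyl on a saturated ring carbon. Among the compounds with values here, three measured steps bear on this spot. The step of a number 60 percentage points lower from compound 1 to compound 2 (beyond the scatter) and the step of a number 70 percentage points lower from compound 1 to compound 3 (beyond the scatter) were both large, whereas the step of a number 10 percentage points lower from compound 2 to compound 3 (within the scatter) stayed within the scatter. The change from compound 3 to compound 4 again exchanges one six-membered aromatic ring of carbon only for another of the same size, much as compound 2 and compound 3 do between themselves. For compound 4 the expected step is therefore a number 5 percentage points higher from compound 3 to compound 4 (within the scatter), that is, none beyond the scatter. Compound 4 is estimated to give 25% in this assay, within a range from 5% to 50%.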

Compound 4, a percentage reported as activity, at one concentration (the size of the read-out at that concentration, not a potency): 90%
Compound 4: the middle estimate sits 65 percentage points below what was measured; the whole stated range lies below it.
By their numbers in this assay, from the lowest: compounds 3 and 2 (each within the scatter of the next); then compounds 1 and 4 (each within the scatter of the next).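

The exchange of 2-chlorophenyl for 4-methylphenyl keeps the heavy-atom count and the one six-membered aromatic ring of carbon only, yet in this assay it gives a number 70 percentage points higher from compound 3 to compound 4 (beyond the scatter) on the saturated ring carbon, and the exchange of 3-nitrophenyl for 4-methylphenyl gives a number 60 percentage points higher from compound 2 to compound 4 (beyond the scatter) on the same carbon. Before this result only 2-hydroxynaphthalen-1-yl stood apart from the other groups, but no change at the digits printed from compound 1 to compound 4 (within the scatter) shows that among these compounds that group is not required for a number of this size, since a single substituted phenyl ring reaches it too. Nothing measured on these compounds accounts for the large steps at this position.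

The move from 2-chlorophenyl to 4-methylphenyl alters both the substituent and its numbered place on the phenyl ring, so the compounds shown leave open which of the two goes with the step. Also open, from the compounds shown here alone, is how the read-out would respond if the methyl of 4-methylphenyl gave way to an amine, a carboxylic acid or a longer alkyl chain.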